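The source may report more compounds than this note shows. Statements on the series, on what has been measured and on what is new or still open speak of the compounds shown alone.

Measured so far:
compound 1, `COc1cc(Br)cc(/C=C/C(=O)c2ccccc2)c1O`, 34.4%
compound 2, `COC(=O)C1=C(N)Oc2c(OC)cc(Br)cc2C1CC(=O)c1ccc(Cl)cc1`, 40.9%
compound 3, `COc1cc(Br)cc2c1OC(N)=C(C#N)C2CC(=O)c1ccccc1`, 45.9%

In an ADME assay on MCF-10A cells (Homo sapiens) for cytotoxicity, read by sulforhodamine B assay, with a stated time of 72 h, tested at 10 uM (on this read-out higher numbers stand for a stronger effect at the one concentration tested and lower numbers for a weaker effect), compound 3 gives 45.9%, the highest of the three numbers; compound 2 sits within the scatter of it, while compound 1 lies beyond the scatter on the lower side. For the measured compounds named here, no measured pair of compounds differs in one place only, so none of these gaps is read as a step tied to a single change.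

Compound 4, `COc1cc(Br)cc2c1OC(N)=C(C#N)C2CC(=O)c1ccc(Cl)cc1`, differs from compound 3 by chloro in place of hydrogen on an aromatic carbon. Going by the values given here, no measured pair isolates this change. Among the compounds with values here, compound 2 carries the same chloro group but differs from compound 3 elsewhere as well; in this assay compound 2 gives 40.9%, which says only that a chlorinated member of the series lands within the scatter of compound 3.

On that basis the step of a number 1.9 percentage points lower from compound 3 to compound 4 (within the scatter) is expected to be small, not beyond the scatter, in either direction. Compound 4 is estimated at 44% in this assay, with a range from 30% to 58%.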

Compound 4, a percentage reported as activity, at one concentration (the size of the read-out at that concentration, not a potency): 36.8%
Beside the measured number, compound 4's estimate is 7.2 percentage points above it; the measured number falls inside the stated range.
By their numbers in this assay, from the lowest: compounds 1, 4, 2 and 3 (each within the scatter of the next, the first and the last beyond it).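

In this assay, chloro in place of hydrogen on an aromatic carbon, para to a large group, now has its own single-place reading: a number 9.1 percentage points lower from compound 3 to compound 4 (within the scatter), so phenyl to 4-chlorophenyl is not shown to shift the read-out at this position. With the 4-chlorophenyl held constant, cyano in place of methoxycarbonyl on a double-bonded ring carbon gives a number 4.1 percentage points lower from compound 2 to compound 4 (within the scatter), so that swap is not separated from the scatter either. No measured evidence bears on either step.

From the compounds shown here alone, whether an amine or a carboxylic acid on this aromatic carbon would give a step beyond the scatter remains open. Also open, going by these compounds, is how chloro in place of hydrogen reads when methoxycarbonyl replaces the cyano group.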